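A few compounds are considered here, and "the series" means these few. Any claim that something is new, unique, unknown or untested is made for them only; others in the source may bear on it.

Compound 2 `O=c1oc2ccccc2cc1C1=NN(c2ccccc2)[C@@H](c2ccccc2[N+](=O)[O-])C1` gives 24.7% in a functional assay on the whole organism (strain albino) for inhibition, with Rattus norvegicus as the target, read by paw edema, with stated times of 1 h and 2 h, at a dose of 200 mg/kg by the oral route (a lower number here means less inhibition, a higher number more inhibition at the dose given (going by the name of the read-out)), where it stands together with compound 1 `CN(C)c1ccc([C@H]2CC(c3cc4ccccc4oc3=O)=NN2c2ccccc2)cc1`, which gives 28.4%, the step of a number 3.7 percentage points lower from compound 1 to compound 2 (within the scatter) falling within the scatter. Compound 3 `O=c1oc2ccccc2cc1C1=NN(c2ccccc2)[C@@H](c2ccc(O)cc2)C1` differs from compound 2 by 4-hydroxyphenyl in place of 2-nitrophenyl on a saturated ring carbon. Among the compounds with values here, the only step recorded at this saturated ring carbon, a number 3.7 percentage points lower from compound 1 to compound 2 (within the scatter), stayed within the scatter, so no movement beyond the scatter is expected here either. Compound 3 is therefore estimated at 26%, within 15% to 37%. The expected step of a number 1.3 percentage points higher from compound 2 to compound 3 (within the scatter) is of no size beyond the scatter.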

Compound 3, a percentage reported as inhibition, in the whole organism at one dose (the size of the read-out at that dose, not a potency): 28.8%
Beside the measured number, compound 3's estimate is 2.8 percentage points below it; low and high end bracket the measured number.
By their numbers in this assay, from the lowest: compounds 2, 1 and 3 (each within the scatter of the next).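

In this assay the step of a number 4.1 percentage points higher from compound 2 to compound 3 (within the scatter) stays within the scatter, even though 4-hydroxyphenyl brings a hydrogen-bond donor that 2-nitrophenyl lacks. The step of a number 0.4 percentage points higher from compound 1 to compound 3 (within the scatter), hydroxy in place of dimethylamino on an aromatic carbon, also stays within the scatter, so the three aryl groups on this saturated ring carbon in compound 1, compound 2 and compound 3 read alike. No supporting data bear on this result. Open, as far as these compounds go, is whether a carboxylic acid on this phenyl ring, or a cyclohexyl group in its place, would move the number beyond the scatter.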